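Amino Substituent on the Aryl Ring of Compound 3

The source may hold more compounds than are shown below. What is called first, only, known or untested is meant among the compounds shown, and "the series" means these compounds.

Three compounds share one core. Compound 1 `COC(=O)C1(c2ccc([N+](=O)[O-])cc2)CC1CN1CCN(c2ccccn2)CC1` gives 769 nM in an assay for displacement of a labelled ligand from Sigma non-opioid intracellular receptor 1 (Cavia porcellus) (a lower number here means a stronger inhibitor, a higher number a weaker inhibitor), compound 2 `COC(=O)C1(c2ccc(Cl)cc2)CC1CN1CCN(c2ccccn2)CC1` gives 707 nM, and compound 3 `COC(=O)C1(c2ccccc2)CC1CN1CCN(c2ccccn2)CC1` gives 1330 nM, the highest of the three numbers, although both other compounds lie within the scatter of it. Compound 4 `COC(=O)C1(c2ccc(N)cc2)CC1CN1CCN(c2ccccn2)CC1` differs from compound 3 by amino in place of hydrogen on an aromatic carbon. Among the measured compounds shown here, the measured steps that bear on this change are a 1.7-fold higher number from compound 1 to compound 3 (0.24 log units; within the scatter) and a 1.9-fold higher number from compound 2 to compound 3 (0.27 log units; within the scatter), both within the scatter; no measured pair carries an amino group. The step in this assay is therefore expected to stay within the scatter, with no clear direction, so the expected step reads a 1.3-fold lower number from compound 3 to compound 4 (0.12 log units; within the scatter). Compound 4 is estimated at 1000 nM, between 400 nM and 2500 nM.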

Compound 4, inhibition constant: > 10000 nM
Compound 4 was reported as a limit; the forecaster's own chance of this, stated with the estimate: 5%; middle value at least 10-fold (1.00 log units) from the limit.
By their numbers in this assay, from the lowest: compounds 2, 1 and 3 (each within the scatter of the next). At a limit, above all of these: compound 4.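

In this assay compound 4 is reported only as a limit, > 10000 nM. Among the compounds shown here, compound 1, compound 2 and compound 3 lie within the scatter of one another, so the earlier compounds showed no sensitivity to the group at this position on the aromatic ring. Amino is the first group to separate from them, with an at least 7.5-fold higher number from compound 3 to compound 4 (0.87 log units; beyond the scatter), an at least 14-fold higher number from compound 2 to compound 4 (1.15 log units; beyond the scatter) and an at least 13-fold higher number from compound 1 to compound 4 (1.11 log units; beyond the scatter).

From the compounds shown here alone, how far past the limit compound 4 lies stays open. Also open, going by these compounds, is whether a hydroxyl, a methylamino or an acetamido group at this place would follow amino or chloro.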